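The source may hold more compounds than are shown below. What is called first, only, known or untested is meant among the compounds shown, and "the series" means these compounds.

In an ADME assay on CCRF-CEM cells (Homo sapiens) for cytotoxicity, with a stated time of 5 days (on this read-out higher numbers stand for weaker inhibition and lower numbers for stronger inhibition), compound 1 (`C=CCNc1ncnc2c1ncn2[C@H]1C[C@H](N=[N+]=[N-])[C@@H](CO)O1`) gives only a limit (> 100000 nM). Compound 2 (`C=CCNc1nc(N)nc2c1ncn2[C@H]1C[C@H](N=[N+]=[N-])[C@@H](CO)O1`) also gives only a limit (> 100000 nM). Compound 2 therefore has no number of its own and stands with compound 1 at the same limit (the limit of > 100000 nM in this assay, at which 2 of the 3 values shown sit). Compound 3 (`[N-]=[N+]=N[C@H]1C[C@H](n2cnc3c(Cl)nc(F)nc32)O[C@@H]1CO`) lacks the allylamino group and gives an actual number (13300 nM).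

Compound 4 (`C=CCN(C)c1nc(N)nc2c1ncn2[C@H]1C[C@H](N=[N+]=[N-])[C@@H](CO)O1`) arises from compound 2 by putting methyl in place of hydrogen on a nitrogen on an aromatic ring, so that allylamino becomes allyl(methyl)amino (methyl in place of hydrogen on a nitrogen on an aromatic ring). The one measured step among these compounds (a step that the two limits leave unreadable from compound 1 to compound 2) is a different change, amino in place of hydrogen on an aromatic carbon, and it offers no size to carry over. No step beyond the usual scatter is therefore expected, and any readable movement could only run toward lower numbers, meaning stronger inhibition. The expected step (a number no higher from compound 2 to compound 4 (the limit leaves the size open)) is small. For compound 4 the expected value is 100000 nM (estimated range 30000 nM to 200000 nM).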

Compound 4, half-maximal inhibitory concentration: 27000 nM
Beside the measured number, compound 4's estimate is 3.7-fold (0.57 log units) above it; the measured number lies below the stated range.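

On the nitrogen on an aromatic ring, methyl in place of hydrogen turns allylamino into allyl(methyl)amino, and in this assay this gives the only readable step among these compounds: an at least 3.7-fold lower number from compound 2 to compound 4 (0.56 log units; beyond the scatter). A single added carbon at this position is therefore enough to bring a compound with the allylamino side chain to a measured number, in the direction of stronger inhibition. The true size of the step stays unknown because compound 2 has only a limit and no number of its own: the limit of > 100000 nM in this assay, at which 2 of the 4 values shown sit.

The compounds shown leave open whether a longer chain such as ethyl on the same nitrogen would go further than methyl or lose the effect. They also leave open whether methyl on this nitrogen would lower the number on the core of compound 1, which has no amino group on the aromatic carbon.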